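A few compounds are considered here, and "the series" means these few. Any claim that something is new, unique, unknown or untested is made for them only; others in the source may bear on it.

Measured so far:
Compound 1, `CC1(C)[C@H]2CC[C@]1(C)N(Cc1cn(-c3ccccc3O)nn1)C(=O)C2`: 120 nM in a functional assay on HepG2 cells (Homo sapiens) for inhibition, read by MTT assay, with a stated time of 24 h; on this read-out higher numbers stand for weaker inhibition and lower numbers for stronger inhibition
Compound 2, `CC1(C)[C@H]2CC[C@]1(C)N(Cc1cn(-c3cccc(F)c3)nn1)C(=O)C2`: 80 nM in this assay

Within the data shown here, compound 2 stands at the lower end of these two numbers, but the only measured step, a 1.5-fold lower number from compound 1 to compound 2 (0.18 log units; within the scatter), lies within the scatter, so the two values cannot be told apart. Compound 3, `COc1cccc(-n2cc(CN3C(=O)C[C@@H]4CC[C@@]3(C)C4(C)C)nn2)c1`, is not yet measured; it differs from compound 2 by methoxy in place of fluoro on an aromatic carbon. That single earlier step is the only one that bears on this change, and it exchanged one group on the phenyl ring for another without a shift beyond the scatter. A similar outcome is expected here: for compound 3 the estimated step is a 1.3-fold higher number from compound 2 to compound 3 (0.10 log units; within the scatter), giving an expected value of 100 nM, between 40 nM and 250 nM.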

Compound 3, half-maximal inhibitory concentration: 70 nM
Beside the measured number, compound 3's estimate is 1.4-fold (0.15 log units) above it; the measured number falls inside the stated range.
By their numbers in this assay, from the lowest: compounds 3, 2 and 1 (each within the scatter of the next).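

In this assay, methoxy in place of fluoro on the six-membered aromatic ring leaves the number within the scatter (a 1.1-fold lower number from compound 2 to compound 3 (0.06 log units; within the scatter)), so this position accepts a larger group carrying a hydrogen-bond acceptor with no shift that can be told apart. Set against the 2-hydroxyphenyl compound, the 3-methoxyphenyl group also stays within the scatter (a 1.7-fold lower number from compound 1 to compound 3 (0.23 log units; within the scatter)). Nothing available explains why these changes show no clear shift. From the compounds shown here alone, whether an amine, a carboxylic acid or a longer chain at this position would move the number beyond the scatter remains open.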